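This account rests on a few compounds, and the source may have more. Where it says the series, first, only, none or still open, it means among the compounds named here.

Of the compounds shown here, two on the shared core have been measured so far in an ADME assay on microsomes from liver (Homo sapiens) for metabolic stability, read by LC-MS, using NADPH, with stated times of 5 min and 30 min, tested at 1 uM (on this read-out higher numbers stand for fast clearance and lower numbers for slow clearance), and their numbers lie within the scatter of each other. Compound 2 (`O=C(Nc1cnc(NCc2c(F)ccc3c2CCO3)n2cnnc12)c1ccccc1`) gives 10 mL.min-1.g-1 there and compound 1 (`CC1(C)CC(=O)N(c2cnc(NCc3c(F)ccc4c3CCO4)n3cnnc23)C1`) gives 16 mL.min-1.g-1 on the same read-out, so compound 2 has that one neighbour and no other. The change to compound 3 (`C[C@H]1CC(=O)N(c2cnc(NCc3c(F)ccc4c3CCO4)n3cnnc23)C1`) is 4-methyl-2-oxopyrrolidin-1-yl in place of benzamido on an aromatic carbon and it falls on an aromatic carbon of a six-membered aromatic ring with 2 nitrogen. Among the compounds with values here, one measured step bears on this: a 1.6-fold lower number from compound 1 to compound 2 (0.20 log units; within the scatter) for benzamido in place of 4,4-dimethyl-2-oxopyrrolidin-1-yl on that carbon. Within the data shown here, the entering 4-methyl-2-oxopyrrolidin-1-yl shares its name, apart from the second methyl, with the group of compound 1, and no measurement yet isolates that methyl. A step beyond the scatter is therefore not expected in this assay and the likeliest direction is only a slight lean towards the number of compound 1. The expected size is a 1.4-fold higher number from compound 2 to compound 3 (0.15 log units; within the scatter) and it stays within the scatter. Compound 3 is estimated at 14 mL.min-1.g-1 in this assay with an expected range from 7 mL.min-1.g-1 to 28 mL.min-1.g-1 as its bounds.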

Compound 3, intrinsic clearance in microsomes in the Homo sapiens assay: < 3 mL.min-1.g-1
Compound 3 gave a limit, no number (the forecaster's own chance of this, stated with the estimate: 5%); middle value at least 4.6-fold (0.66 log units) from the limit.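

Within the data shown here, in the Homo sapiens assay, the change at this aromatic carbon gives an at least 3.3-fold lower number from compound 2 to compound 3 (0.52 log units; beyond the scatter), the first step here to lie beyond the scatter, whereas the step between compound 1 and compound 2 stayed within it. The comparison with the 4,4-dimethyl-2-oxopyrrolidin-1-yl group, an at least 5.3-fold lower number from compound 1 to compound 3 (0.72 log units; beyond the scatter), differs by a single methyl and shows that 4-methyl-2-oxopyrrolidin-1-yl and 4,4-dimethyl-2-oxopyrrolidin-1-yl are not interchangeable on this read-out, so the similarity of their names was a poor guide. In a physicochemical assay for solubility, read by LC-MS, in phosphate buffer, with a stated time of 24 h, at pH 7.4 (on this read-out higher numbers stand for higher solubility and lower numbers for lower solubility), compound 2 gives 2000 nM and compound 3 gives 200000 nM. Replacing benzamido with 4-methyl-2-oxopyrrolidin-1-yl also moves the physicochemical assay well beyond the scatter, so the lower clearance number comes with higher, not lower, solubility: the measured solubility of compound 2, 2000 nM, and of compound 3, 200000 nM, a 100-fold higher number (2.00 log units; beyond the scatter)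

As far as these compounds go, in the Homo sapiens assay, compound 3 stands at a limit and not at a number, so the true size of both steps stays open: the limit of < 3 mL.min-1.g-1 in the Homo sapiens assay, at which 1 of the 3 values shown sits. Also open is whether the unsubstituted 2-oxopyrrolidin-1-yl, the opposite configuration at the methyl-bearing stereocentre, or an open-chain acetamido group would match compound 3 on this read-out.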